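This account rests on a few compounds, and the source may have more. Where it says the series, first, only, none or still open, it means among the compounds named here.

Compound 3 `Oc1cccc(-c2cc(-c3ccc(OC(F)(F)F)cc3)cc(-c3ccccc3O)n2)c1` gives 7710 nM in a functional assay on T47D cells (Homo sapiens) for inhibition (on this read-out lower numbers stand for stronger inhibition and higher numbers for weaker inhibition), the higher of the two numbers recorded there. Compound 2 `Oc1ccc(-c2cc(-c3ccc(C(F)(F)F)cc3)cc(-c3cccc(O)c3)n2)cc1` gives 2870 nM in this assay. Compound 1 `Oc1cccc(-c2cc(-c3ccc(C(F)(F)F)cc3)cc(-c3ccccc3O)n2)c1` returns only a limit of the assay, > 50000 nM, and no number; this is the limit of > 50000 nM in this assay, at which 1 of the 3 values shown sits.

Compound 4 `Oc1ccc(-c2cc(-c3ccc(OC(F)(F)F)cc3)cc(-c3cccc(O)c3)n2)cc1` differs from compound 3 by 4-hydroxyphenyl in place of 2-hydroxyphenyl on an aromatic carbon. The same exchange has been measured once, on the pair that carries trifluoromethyl instead of trifluoromethoxy: there it produced an at least 17-fold lower number from compound 1 to compound 2 (1.24 log units; beyond the scatter), a step that starts from a limit and so can only be stated as a lower bound. The other change within the set, an at least 6.4-fold lower number from compound 1 to compound 3 (0.81 log units; beyond the scatter), also begins at that limit. Among the measured compounds shown here, both measured steps thus point the same way, toward lower numbers, and the one that matches the change from compound 3 to compound 4 is the larger of the two.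

A lowering of at least that size is therefore expected, so compound 4 is estimated to show a 17-fold lower number from compound 3 to compound 4 (1.23 log units; beyond the scatter) in this assay. Allowing for the lower bound being only a bound, compound 4 is expected to give about 450 nM, within a range from 120 nM to 1800 nM.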

Compound 4, half-maximal inhibitory concentration: 18900 nM
Estimate against measurement, compound 4: 42-fold (1.62 log units) below; the measured number lies above the stated range.
By their numbers in this assay, from the lowest: compound 2; then compound 3; then compound 4. At a limit, above all of these: compound 1.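

In this assay, 4-hydroxyphenyl in place of 2-hydroxyphenyl, on the aromatic carbon next to the ring nitrogen, now gives a 2.5-fold higher number from compound 3 to compound 4 (0.39 log units; beyond the scatter), so the effect of this change depends on the group carried elsewhere on the core and does not carry over from the trifluoromethyl pair to the trifluoromethoxy pair: the same change on two cores in this assay, an at least 17-fold lower number (1.24 log units; beyond the scatter) from compound 1 to compound 2 and a 2.5-fold higher number (0.39 log units; beyond the scatter) from compound 3 to compound 4, at least 42-fold (1.63 log units) apart, beyond the scatter of two such steps The second change turns around in the same way, for trifluoromethoxy in place of trifluoromethyl gives a 6.6-fold higher number from compound 2 to compound 4 (0.82 log units; beyond the scatter) when 4-hydroxyphenyl is present, whereas it went the opposite way with 2-hydroxyphenyl: the same change on two cores in this assay, an at least 6.4-fold lower number (0.81 log units; beyond the scatter) from compound 1 to compound 3 and a 6.6-fold higher number (0.82 log units; beyond the scatter) from compound 2 to compound 4, at least 42-fold (1.63 log units) apart, beyond the scatter of two such steps In these four compounds, the two places therefore do not act independently on this read-out, and neither change can be judged apart from the other.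

From the compounds shown here alone, it remains open how an aminophenyl or a methoxyphenyl group would behave at this position on either core, and so whether the hydroxyl itself matters there. Going by these compounds, it is equally open whether the same dependence would appear with a chlorine or a nitrile in place of trifluoromethyl and trifluoromethoxy.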